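Replacing Bromo with Methyl in a Weak Growth Inhibitor

The source may hold more compounds than are shown below. What is called first, only, known or untested is meant among the compounds shown, and "the series" means these compounds.

Going by the values given here, in a functional assay on U-251 cells (Homo sapiens) for inhibition, read by sulforhodamine B assay, with a stated time of 48 h (a lower number here means a stronger inhibitor of growth, a higher number a weaker inhibitor of growth), compound 2 `CC(C)(C)NCc1c(C(=O)O)nn(-c2ccccc2)c1-c1ccc(Br)cc1` gives 126000 nM, the only true number so far. Compound 1 `CC(C)(C)NCc1c(C(=O)O)nn(-c2ccccc2)c1-c1ccc(F)cc1` reads > 680000 nM, which is a limit of the assay. Compound 3 `Cc1ccc(-c2c(CNC(C)(C)C)c(C(=O)O)nn2-c2ccccc2)cc1` differs from compound 2 by methyl in place of bromo on an aromatic carbon. Among the compounds with values here, one measured step bears on this change: an at least 5.3-fold lower number from compound 1 to compound 2 (0.73 log units; beyond the scatter), with bromo in place of fluoro. Within the data shown here, with only that guide, a modest move toward a higher number in this assay is expected. The expected step is a 2.1-fold higher number from compound 2 to compound 3 (0.31 log units; beyond the scatter). For compound 3 the estimate is 260000 nM, with an expected range of 90000 nM to 680000 nM.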

Compound 3, concentration for 50% growth inhibition: > 688000 nM
Compound 3 was reported as a limit (the forecaster's own chance of this, stated with the estimate: 30%); at least 2.6-fold (0.42 log units) between middle value and limit.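

In this assay, replacing bromo with methyl gives an at least 5.4-fold higher number from compound 2 to compound 3 (0.73 log units; beyond the scatter), so a second replacement of bromo at this position, with methyl as with fluoro, leads to a limit rather than a true number. Compound 3 reads > 688000 nM, which is a limit of the assay. Among the three groups shown at this position, only bromo gives a true number, and the step between the fluoro and methyl compounds cannot be read.

As far as these compounds go, whether chloro or iodo at this position would read like bromo remains open. So does whether methoxy would give a true number.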